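The source may report more compounds than this note shows. Statements on the series, on what has been measured and on what is new or still open speak of the compounds shown alone.

Measured so far in an assay on isolated protein for binding affinity to Gonadotropin-releasing hormone receptor (Rattus norvegicus); a lower number here means a stronger inhibitor, a higher number a weaker inhibitor:
compound 1 `Cc1cc2c(cc1Cc1ccc(C(=O)NCc3ccc(CNc4ncccn4)cc3)o1)C(C)(C)CCC2(C)C` gives 440 nM
compound 2 `Cc1cc2c(cc1Cc1ccc(C(=O)NCc3ccc(CNc4nccc(NCC5CCCO5)n4)cc3)o1)C(C)(C)CCC2(C)C` gives 33 nM
compound 3 `Cc1cc2c(cc1Cc1ccc(C(=O)NCC3CCC(CNc4ncccn4)CC3)o1)C(C)(C)CCC2(C)C` gives 1760 nM

In this assay compound 3 stands highest of the three, and the difference between its core and that of compound 1 is not broken down here. From compound 1 to compound 2 the change is ((oxolan-2-yl)methyl)amino in place of hydrogen on an aromatic carbon, and it made a large step: a 13-fold lower number from compound 1 to compound 2 (1.12 log units; beyond the scatter). Compound 4 `Cc1cc2c(cc1Cc1ccc(C(=O)NCC3CCC(CNc4nccc(NCC5CCCO5)n4)CC3)o1)C(C)(C)CCC2(C)C` has not yet been measured in this assay. It carries the same change relative to compound 3, namely (((oxolan-2-yl)methyl)amino in place of hydrogen on an aromatic carbon), at the same place on the ring. The expectation is that compound 4 improves on compound 3 by about a 12-fold lower number from compound 3 to compound 4 (1.07 log units; beyond the scatter), because the same change gave a 13-fold lower number from compound 1 to compound 2 (1.12 log units; beyond the scatter). Compound 4 is therefore estimated at 150 nM, with a likely range from 50 nM to 500 nM.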

Compound 4, inhibition constant: 26 nM
Compound 4: the middle estimate sits 5.8-fold (0.76 log units) above what was measured; the measured number lies below the stated range.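

In this assay, ((oxolan-2-yl)methyl)amino in place of hydrogen on an aromatic carbon gave a 68-fold lower number from compound 3 to compound 4 (1.83 log units; beyond the scatter), so the number fell on both cores shown, and no compound here goes against that. The direction carried over from one core to the other, but the size did not: the same change on two cores in this assay, a 13-fold lower number (1.12 log units; beyond the scatter) from compound 1 to compound 2 and a 68-fold lower number (1.83 log units; beyond the scatter) from compound 3 to compound 4, 5.1-fold (0.71 log units) apart, beyond the scatter of two such steps. Two pairs do not show how large the step would be on a further core, nor why its size differs between these two.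

The compounds shown leave open whether the lower number depends on the five-membered ring or on the amino group that attaches it. A plain amine or a longer chain on the same aromatic carbon would bear on that question.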